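The source may report more compounds than this note shows. Statements on the series, on what has been measured and on what is new or still open speak of the compounds shown alone.

Measured so far:
Compound 1 `CCC1=C(O)c2c(oc(-c3ccc(OC(F)(F)F)cc3)cc2=O)C(CC)(CC)C1=O` gives 36.5 uM in a functional assay on KB cells (Homo sapiens) for antiproliferative activity, read by sulforhodamine B assay, with a stated time of 3 days; a lower number here means that less compound is needed, a higher number that more compound is needed for the effect.
Compound 2 `CCC1=C(O)c2c(oc(-c3ccc(CBr)cc3)cc2=O)C(CC)(CC)C1=O` gives only a limit, > 46.5 uM, in this assay.

Compound 2 stands at the floor of this assay without a number of its own; the limit of > 46.5 uM in this assay, at which 1 of the 2 values shown sits, marks where one of the two values sits. For the measured compounds named here, the sole measured step, an at least 1.2-fold higher number from compound 1 to compound 2 (0.10 log units; that floor lies within the scatter), is itself only a floor and lies within the scatter, so it shows no direction for a swap of the group on this aromatic carbon. Compound 3 `CCC1=C(O)c2c(oc(-c3ccc(C)c(Cl)c3)cc2=O)C(CC)(CC)C1=O` differs from compound 2 by 3-chloro-4-methylphenyl in place of 4-(bromomethyl)phenyl on an aromatic carbon. Going by the values given here, no measured step involves 3-chloro-4-methylphenyl, and the step from compound 1 to compound 2 is the only one that touches this position. No step beyond the scatter is expected in this assay in either direction, and a further limit remains possible. The estimate for compound 3 is 40 uM, with range 15 uM to 150 uM. For compound 3 the expected step is an at least 1.1-fold lower number from compound 2 to compound 3 (0.06 log units; that floor lies within the scatter).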

Compound 3, concentration for half-maximal effect: 39 uM
Compound 3: middle estimate off by 1.0-fold (0.01 log units), on the high side, within the range that was stated.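

The change to 3-chloro-4-methylphenyl gives an at least 1.1-fold lower number from compound 2 to compound 3 (0.07 log units; that floor lies within the scatter), so, like the earlier step at this position, it shows no direction. Compound 2 still has no number of its own, only a limit: the limit of > 46.5 uM in this assay, at which 1 of the 3 values shown sits. What is new is a second measured number at this position: in this assay compound 1 gives 36.5 uM and compound 3 gives 39 uM, so two differently substituted phenyl groups now carry values within the scatter of each other.

As far as these compounds go, whether any group here can move the number beyond the scatter remains open, for instance an amine or a carboxylic acid on this phenyl ring. Also open, from the compounds shown here alone, is the real value of compound 2, and with it the size of both steps that touch it.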